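The source may report more compounds than this note shows. Statements on the series, on what has been measured and on what is new or still open speak of the compounds shown alone.

Measured so far in an ADME assay on NIH3T3 cells (Mus musculus) for cytotoxicity, read by XTT assay, with a stated time of 24 h; a higher number here means a weaker inhibitor, a lower number a stronger inhibitor:
Compound 1 `Fc1ccc(C2CC(c3ccc(Cl)s3)=NN2c2nc(-c3ccc(C(F)(F)F)cc3)cs2)cc1` gives > 500 ug/mL, a limit of the assay.
Compound 2 `Cc1ccc(-c2csc(N3N=C(c4ccc(Cl)s4)CC3c3ccc(F)cc3)n2)cc1` gives > 500 ug/mL, a limit of the assay.
Compound 3 `N#Cc1ccc(-c2csc(N3N=C(c4ccc(Cl)s4)CC3c3ccc(F)cc3)n2)cc1` gives > 500 ug/mL, a limit of the assay.

Within the data shown here, compound 3 therefore stands only at the limit of this assay, the point where every value so far sits (the limit of > 500 ug/mL in this assay, at which 3 of the 3 values shown sit); no number places it relative to compound 1 or compound 2. The steps a step that the two limits leave unreadable from compound 1 to compound 2, a step that the two limits leave unreadable from compound 1 to compound 3 and a step that the two limits leave unreadable from compound 2 to compound 3 are all unreadable for the same reason, so none of them gives a size to carry forward.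

Compound 4 `Fc1ccc(-c2csc(N3N=C(c4ccc(Cl)s4)CC3c3ccc(F)cc3)n2)cc1` differs from compound 3 by fluoro in place of cyano on an aromatic carbon. With no readable step in this assay, no shift beyond the scatter is expected for compound 4, and most likely only a limit will be reported again. The estimate for compound 4 in this assay is 600 ug/mL, range 300 ug/mL to 2000 ug/mL. The expected step is a step that the limit leaves unreadable from compound 3 to compound 4.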

Compound 4, half-maximal inhibitory concentration: > 500 ug/mL
Compound 4 ended at the assay's limit; the forecaster's own chance of this, stated with the estimate: 85%; the middle value is on the limit's open side.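

The steps from compound 1, compound 2 and compound 3 to compound 4 cannot be read, as all four values are limits: the limit of > 500 ug/mL in this assay, at which 4 of the 4 values shown sit.

From the compounds shown here alone, whether these four compounds differ at all in this assay remains open.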